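A few compounds are considered here, and "the series" means these few. Any claim that something is new, unique, unknown or untested is made for them only; others in the source may bear on it.

Measured compounds:
compound 1, `Fc1cccc(F)c1C#Cc1nccc2ccccc12`, gives 35.4% in a functional assay on LS174T cells (Homo sapiens) for inhibition, with a stated time of 4 days, tested at 1 uM; on this read-out lower numbers stand for a weaker effect and higher numbers for a stronger effect at the one concentration tested
compound 2, `Fc1ccc2ccnc(C#Cc3c(F)cccc3F)c2c1`, gives 71.1% in this assay
compound 3, `Fc1cccc(F)c1C#Cc1cnc2ccccc2c1`, gives 41.7% in this assay

Compound 2 arises from compound 1 by one change, (fluoro in place of hydrogen on an aromatic carbon), and that change brought a number 35.7 percentage points higher from compound 1 to compound 2 (beyond the scatter). Compound 1 and compound 3 have the same atoms joined differently; the difference between the two cores is not broken down here. Compound 3 stands within the usual scatter of compound 1, and compound 2 stands beyond the scatter above both.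

Compound 4, `Fc1ccc2cc(C#Cc3c(F)cccc3F)cnc2c1`, is not yet measured. Among the compounds with values here, it arises from compound 3 by fluoro in place of hydrogen on an aromatic carbon, which is the same change, at a place described in the same words, as the one separating compound 1 from compound 2. Within the data shown here, since compound 3 starts close to where compound 1 started, compound 4 is expected to show a gain of about a number 24.3 percentage points higher from compound 3 to compound 4 (beyond the scatter) in this assay, resting on the single earlier step of a number 35.7 percentage points higher from compound 1 to compound 2 (beyond the scatter), though one step alone is a thin basis and the range is kept wide. Compound 4 is therefore estimated at 66%, expected to fall between 44% and 84%.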

Compound 4, a percentage reported as inhibition, at one concentration (the size of the read-out at that concentration, not a potency): 69.4%
Compound 4: middle estimate off by 3.4 percentage points, on the low side, and the stated range covers the measured number.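

In this assay, replacing hydrogen with fluoro on an aromatic carbon gave a number 27.7 percentage points higher from compound 3 to compound 4 (beyond the scatter). Set beside the earlier step, the change carried from one core to the other with a gain of similar size: the same change on two cores in this assay, a number 35.7 percentage points higher (beyond the scatter) from compound 1 to compound 2 and a number 27.7 percentage points higher (beyond the scatter) from compound 3 to compound 4, 8 percentage points apart, within the scatter of two such steps This shows that the gain held on the two cores examined at the single concentration tested, but it does not show that it would hold on a further core, and a read-out at one concentration does not establish a change in potency.

The compounds shown leave open whether a group other than fluoro, such as chloro, methoxy or an amine, on the same aromatic carbon would give a similar gain. They also leave open what would follow if the two fluoro groups on the separate ring, which stay unchanged across all four compounds, were replaced by a nitrile or a trifluoromethyl group.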